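This account rests on a few compounds, and the source may have more. Where it says the series, first, only, none or still open, it means among the compounds named here.

Within the data shown here, compound 1 `O=c1c2cnn(-c3ccc(F)cc3)c2ncn1CC1(O)CCN(Cc2ccc(Cl)cc2)CC1` is the only compound here with a number attached to it. In an assay on Sf21 cells for inhibition of ubiquitin carboxyl-terminal hydrolase 7 (Homo sapiens), read by spectrophotometry, with stated times of 30 min and 2 h (on this read-out higher numbers stand for weaker inhibition and lower numbers for stronger inhibition), compound 1 gives 8000 nM, which stands for weak inhibition. Compound 2 `O=c1c2cnn(-c3ccc(F)cc3)c2ncn1CC1(O)CCN(Cc2ccc(C(F)(F)F)cc2)CC1` belongs to the same series, but in this assay compound 2 gives "not determined" (no result reported), so it offers no number to set against compound 1. Compound 3 `COC(=O)c1ccc(CN2CCC(O)(Cn3cnc4c(cnn4-c4ccc(F)cc4)c3=O)CC2)cc1` has not been measured at all. It differs from compound 1 in a single place: methoxycarbonyl in place of chloro on an aromatic carbon. Among the measured compounds shown here, no pair of measured compounds shows what such a change does in this assay, so there is no measured step to lean on, and the expectation below rests on compound 1 alone. The step of no change at the digits printed from compound 1 to compound 3 (within the scatter) is expected to be small, none beyond the usual scatter, with the true value possibly lying on either side. With that in mind, compound 3 is estimated to give about 8000 nM in this assay, most likely somewhere between 3000 nM and 25000 nM, with a real chance that only a limit is reported.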

Compound 3, half-maximal inhibitory concentration: 4500 nM
Beside the measured number, compound 3's estimate is 1.8-fold (0.25 log units) above it, and the stated range covers the measured number.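

In this assay, among these compounds, replacing 4-chlorobenzyl with 4-(methoxycarbonyl)benzyl gives a 1.8-fold lower number from compound 1 to compound 3 (0.25 log units; within the scatter), the first measured step at this position on the ring. A single chlorine atom can therefore give way to a methoxycarbonyl group of 4 heavy atoms, including 2 hydrogen-bond acceptors, without a change in the number that stands out from ordinary repeat variation, so this one swap shows that the position tolerates a larger group in this assay. Nothing available explains why the two compounds read alike, and a single step within the scatter cannot separate a small real effect from none at all.

Going by these compounds, it remains open whether any group at this position can move the number beyond the scatter, for example a carboxylic acid, a primary amide, an aminomethyl group or a longer ester chain. On these data alone, it is also open whether a change elsewhere on the shared core would do more, since compound 1 and compound 3 differ only at this one place and both are single readings.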